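This account rests on a few compounds, and the source may have more. Where it says the series, first, only, none or still open, it means among the compounds named here.

Measured compounds in a functional assay on DU-145 cells (Homo sapiens) for inhibition, read by trypan blue exclusion, with a stated time of 96 h; a higher number here means a weaker inhibitor of growth, a lower number a stronger inhibitor of growth:

compound 1 `Cc1ccc(S/C(=C/c2c[nH]c3ccccc23)C(=O)c2ccc(Br)cc2)cc1`: 10000 nM
compound 2 `COc1ccccc1/C=C(/Sc1ccc(C)cc1)C(=O)c1ccc(Br)cc1`: 9000 nM
compound 3 `COc1ccccc1/C=C(/SCc1ccc(F)cc1)C(=O)c1ccc(Cl)cc1`: 10000 nM

Compound 2 and compound 1 share a core and differ in one place, (1H-indol-3-yl in place of 2-methoxyphenyl on a double-bonded chain carbon bound to a double-bonded chain carbon). The resulting step is a 1.1-fold higher number from compound 2 to compound 1 (0.05 log units; within the scatter). Compound 3 differs from compound 2 in more than one place; the difference between the two cores is not broken down here. In this assay compound 3 and compound 1 agree at the digits given, and neither is separated from compound 2 beyond the scatter.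

Compound 4 `O=C(/C(=C\c1c[nH]c2ccccc12)SCc1ccc(F)cc1)c1ccc(Cl)cc1` is not yet measured. It differs from compound 3 by the same change, at the same place, as compound 1 from compound 2: 1H-indol-3-yl in place of 2-methoxyphenyl on a double-bonded chain carbon bound to a double-bonded chain carbon. The step is expected to be about as small, a 1.1-fold higher number from compound 3 to compound 4 (0.02 log units; within the scatter), because the same change gave a 1.1-fold higher number from compound 2 to compound 1 (0.05 log units; within the scatter). Compound 4 is therefore estimated at 10500 nM, expected to fall between 5000 nM and 22000 nM.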

Compound 4, concentration for 50% growth inhibition: 1000 nM
Compound 4: middle estimate off by 11-fold (1.02 log units), on the high side, and the stated range ends above it.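

In this assay, the change from 2-methoxyphenyl to 1H-indol-3-yl does not carry over from one core to the other at a constant size: the same change on two cores in this assay, a 1.1-fold higher number (0.05 log units; within the scatter) from compound 2 to compound 1 and a 10-fold lower number (1.00 log units; beyond the scatter) from compound 3 to compound 4, 11-fold (1.05 log units) apart, beyond the scatter of two such steps

On the core of compound 3, the change gives a 10-fold lower number from compound 3 to compound 4 (1.00 log units; beyond the scatter), so its size here depends on the core it is made on. The two cores differ in more than one place, and these two pairs do not show which of those places sets the size of the step.

Still open, on these data alone, is whether the step on the core of compound 3 persists when the group on sulfur is a longer chain or carries an amine. Also open, as far as these compounds go, is whether a hydroxyphenyl group in place of 1H-indol-3-yl gives a similar step.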